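Swapping an azetidine for a new group: what clearance follows?

The source may report more compounds than this note shows. Statements on the series, on what has been measured and on what is new or still open speak of the compounds shown alone.

Measured in an ADME assay on microsomes from liver (Mus musculus) for metabolic stability, read by LC-MS, using NADPH, with stated times of 10 min and 30 min, tested at 1 uM (a higher number here means faster removal of the compound, a lower number slower removal), so far:
Compound 1 `COC(=O)C1=C(CN2CC3CC2CO3)NC(c2nccs2)=NC1(C)c1ccc(F)cc1`: 84 mL/min/kg
Compound 2 `COC(=O)C1=C(CN2CC(OC)C2)NC(c2nccs2)=NC1(C)c1ccc(F)cc1`: 88 mL/min/kg

Compound 2 gives 88 mL/min/kg and stands level with compound 1, as the two numbers lie within the scatter of each other. Compound 3 `COC(=O)C1=C(CN(C)C2(C(=O)O)CC2)NC(c2nccs2)=NC1(C)c1ccc(F)cc1` has no number yet. It keeps the shared core and changes one group: a group of 8 heavy atoms (5 carbon, 1 nitrogen, 2 oxygen; one three-membered non-aromatic ring of carbon only) in place of a group of 6 heavy atoms (4 carbon, 1 nitrogen, 1 oxygen; one four-membered non-aromatic ring with 1 hetero atom), on a saturated chain carbon bound to a double-bonded ring carbon. The entering group carries a hydrogen-bond donor, which the leaving group lacks.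

Within the data shown here, only one measured step bears on this change: a 1.0-fold higher number from compound 1 to compound 2 (0.02 log units; within the scatter). That step exchanged one ring-bearing group for another and stayed within the scatter. It is a weak guide here, since the group entering compound 3 is of a kind not yet measured on this core. The data show no trend for such a group, so the expectation below is a judgement from the structural change alone. Compound 2, at 88 mL/min/kg, is the starting point, and a lower number is expected, with wide uncertainty. The expected step is a 2.2-fold lower number from compound 2 to compound 3 (0.34 log units; beyond the scatter). For compound 3 the estimated clearance is 40 mL/min/kg, with an expected range of 15 mL/min/kg to 85 mL/min/kg.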

Compound 3, clearance: 42 mL/min/kg
For compound 3 the middle estimate is 1.1-fold (0.02 log units) below the measured one; the measured number falls inside the stated range.
By their numbers in this assay, from the lowest: compounds 3, 1 and 2 (each within the scatter of the next, the first and the last beyond it).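

In this assay, this position, on a saturated chain carbon bound to a double-bonded ring carbon, now shows that a change of group can shift clearance: replacing 3-methoxyazetidin-1-yl with the group bearing a three-membered carbon ring gives a 2.1-fold lower number from compound 2 to compound 3 (0.32 log units; beyond the scatter), whereas the earlier exchange of one ring-bearing group for another stayed within the scatter. The shift is modest and rests on a single comparison, since the same entering group, set against the group of two five-membered rings, gives a 2.0-fold lower number from compound 1 to compound 3 (0.30 log units; within the scatter). Nothing available here explains why the number moved.

The entering group differs from the leaving group in more than one feature, so the compounds shown do not tell which part of it goes with the lower number. On these data alone, a methyl ester or a primary amide in place of the carboxylic acid, or an open chain in place of the three-membered ring, would help to separate these parts, and whether any such step would hold on another core also remains open.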